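Adding a Second Chloro to the Benzyl Ring of Compound 1

The source may hold more compounds than are shown below. What is called first, only, known or untested is meant among the compounds shown, and "the series" means these compounds.

Compound 1 `O=S(=O)(NCCCNCc1ccc(Cl)cc1)c1cc(C(F)(F)F)cc(C(F)(F)F)c1`: 2800 nM
Compound 2 `O=S(=O)(NCCCCCCNCc1ccc(Br)cc1)c1c(Cl)cccc1Cl`: 14700 nM
Compound 3 `O=S(=O)(NCCCCCCNCc1ccc(Br)cc1)c1cc(Cl)cc(Cl)c1`: 12000 nM

In a functional assay on MIA PaCa-2 cells (Homo sapiens) for inhibition, read by MTT assay, with a stated time of 72 h (on this read-out lower numbers stand for stronger inhibition of growth and higher numbers for weaker inhibition of growth), compound 1 gives 2800 nM, the lowest of the three numbers; compound 3 gives 12000 nM and compound 2 gives 14700 nM, both beyond the scatter away from compound 1. Among the measured compounds shown here, the only measured step between neighbours, a 1.2-fold lower number from compound 2 to compound 3 (0.09 log units; within the scatter), concerns the aryl on the sulfonyl sulfur and not the benzyl ring.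

Compound 4 `O=S(=O)(NCCCNCc1ccc(Cl)c(Cl)c1)c1cc(C(F)(F)F)cc(C(F)(F)F)c1` differs from compound 1 in one place: chloro in place of hydrogen on an aromatic carbon, so that 4-chlorobenzyl becomes 3,4-dichlorobenzyl. For the measured compounds named here, no measured step touches the benzyl ring, and the one step that is known lies within the scatter, so there is no basis for a large change in either direction. Compound 4 is therefore expected to sit close to compound 1, the estimated step being a 1.4-fold lower number from compound 1 to compound 4 (0.15 log units; within the scatter). The estimated value of compound 4 in this assay is 2000 nM, with a range from 700 nM to 6000 nM.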

Compound 4, concentration for 50% growth inhibition: 2700 nM
Beside the measured number, compound 4's estimate is 1.4-fold (0.13 log units) below it, within the range that was stated.
By their numbers in this assay, from the lowest: compounds 4 and 1 (each within the scatter of the next); then compounds 3 and 2 (each within the scatter of the next).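

In this assay, the change from 4-chlorobenzyl to 3,4-dichlorobenzyl gives a 1.0-fold lower number from compound 1 to compound 4 (0.02 log units; within the scatter). Among the compounds shown here, this is the only measured step on the benzyl ring, and it shows that a chloro can enter on this aromatic carbon, ortho to the existing chloro group and meta to a large group, without moving the growth-inhibition number beyond the scatter. Nothing available accounts for this outcome.

The compounds shown leave open whether this position would respond in the same way to a group other than chloro, such as a methoxy group, a nitrile, an amine or a carboxylic acid. They also leave open whether the same chloro would have as little effect on the 4-bromobenzyl compounds with the longer chain, compound 2 and compound 3.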